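Chain Extension in a Series of Pepsin Inhibitors

This account rests on a few compounds, and the source may have more. Where it says the series, first, only, none or still open, it means among the compounds named here.

In an assay on isolated protein for inhibition of Pepsin A (Homo sapiens) (a higher number here means a weaker inhibitor, a lower number a stronger inhibitor), compound 1 `CCCCC(O)[C@H](CC(C)C)NC(=O)[C@@H](NC(=O)[C@@H](NC(=O)OC(C)(C)C)C(C)C)C(C)C` gives 1240 nM, and compound 2 `CCCCCCC(O)[C@H](CC(C)C)NC(=O)[C@@H](NC(=O)[C@@H](NC(=O)OC(C)(C)C)C(C)C)C(C)C` gives 830 nM, the lower of the two numbers, though a 1.5-fold lower number from compound 1 to compound 2 (0.17 log units; within the scatter) lies within the scatter. Compound 3 `CCCCCCCCC(O)[C@H](CC(C)C)NC(=O)[C@@H](NC(=O)[C@@H](NC(=O)OC(C)(C)C)C(C)C)C(C)C` differs from compound 2 by ethyl in place of hydrogen on a saturated chain carbon, seven bonds along the chain from an oxygen on a saturated carbon. Within the data shown here, the only comparable step is the one from compound 1 to compound 2, which was small, so the step to compound 3 is expected to be small as well, with a 1.3-fold lower number from compound 2 to compound 3 (0.11 log units; within the scatter) in this assay. Compound 3 is therefore estimated at 650 nM, within a range from 300 nM to 1500 nM.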

Compound 3, half-maximal inhibitory concentration: 790 nM
For compound 3 the middle estimate is 1.2-fold (0.08 log units) below the measured one; measured number inside the range.
By their numbers in this assay, from the lowest: compounds 3, 2 and 1 (each within the scatter of the next).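

In this assay, ethyl in place of hydrogen seven bonds along the chain from an oxygen on a saturated carbon gives a 1.1-fold lower number from compound 2 to compound 3 (0.02 log units; within the scatter), so this further extension stays as small as the one before it. Taken whole, butyl in place of hydrogen gives a 1.6-fold lower number from compound 1 to compound 3 (0.20 log units; within the scatter), so even the summed extension does not leave the scatter. Nothing available accounts for this.

Going by these compounds, whether a longer chain, an amine or a carboxylic acid in this place would move the number beyond the scatter remains open.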